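The source may report more compounds than this note shows. Statements on the series, on what has been measured and on what is new or still open speak of the compounds shown alone.

Two compounds of a shared core carry a trimethoxyanilino group and have been measured in an assay on CHO-K1 cells for binding affinity to adenosine receptor A1 (Homo sapiens), read by NanoBRET; on this read-out higher numbers stand for weaker inhibition and lower numbers for stronger inhibition. Compound 1 `COc1cc(Nc2nc(Cl)cc3c(C(C)C)n[nH]c23)cc(OC)c1OC` gives 288 nM in this assay. Compound 2 `COc1cc(Nc2nc(CN)cc3c(-c4ccccc4)n[nH]c23)cc(OC)c1OC` gives 22.9 nM in this assay, the lowest of the two numbers shown and a gap from compound 1 that lies beyond the usual scatter. Compound 3 `COc1cc(Nc2nc(CNCC3CCN(C)CC3)cc3c(-c4ccccc4)n[nH]c23)cc(OC)c1OC`, not yet measured, differs from compound 2 in one place: (1-methylpiperidin-4-yl)methyl in place of hydrogen on an amine nitrogen. Among the measured compounds shown here, no measured pair in this set shows what such a change on the amine nitrogen does in this assay, so the expectation rests on the shared core alone. A step of a 1.5-fold higher number from compound 2 to compound 3 (0.18 log units; within the scatter) is expected, most likely a small weakening that stays within the scatter or only just beyond it. Compound 3 is therefore estimated at 35 nM in this assay, within a range of 9 nM to 140 nM.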

Compound 3, inhibition constant: 741 nM
Compound 3: middle estimate off by 21-fold (1.33 log units), on the low side; measured number outside the range, above it.
By their numbers in this assay, from the lowest: compound 2; then compound 1; then compound 3.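

In this assay the amine nitrogen of compound 2 turns out not to accept every substituent: (1-methylpiperidin-4-yl)methyl in place of hydrogen on that nitrogen gives a 32-fold higher number from compound 2 to compound 3 (1.51 log units; beyond the scatter) and so lies well beyond the scatter. This is the first step shown at this position, and it makes clear that the number here responds strongly to what the nitrogen carries, which the two earlier compounds could not show. Nothing shown explains why the number rises so far.

The step changes a ring and its linking chain together, so the compounds shown leave open which part of the entering group accounts for it. On these data alone, whether a single methyl, an acetyl group or a plain butyl chain on this nitrogen would keep the number near that of compound 2 also remains open.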